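The source may hold more compounds than are shown below. What is called first, only, known or untested is meant among the compounds shown, and "the series" means these compounds.

Compound 1 `COC(=O)[C@@]1(C)CC[C@@H]2C3=C1CC[C@@H](C)[C@]3(C)C[C@@H]1c3ccccc3N[C@H]21` and compound 2 `COC(=O)[C@@]1(C)CC[C@@H]2C3=C1CC[C@@H](C)[C@]3(C)C[C@@H]1c3cc(C)ccc3N[C@H]21` share one core and differ only in the substituent on the aromatic ring. In a functional assay on SW1573 cells (Homo sapiens) for inhibition, read by sulforhodamine B assay, with a stated time of 48 h (on this read-out higher numbers stand for weaker inhibition of growth and lower numbers for stronger inhibition of growth), compound 1 gives 30000 nM, and compound 2 gives 23000 nM. For the measured compounds named here, the single measured step, a 1.3-fold lower number from compound 1 to compound 2 (0.12 log units; within the scatter), leaves the number essentially unchanged; compound 2 thus holds the lower of the two numbers, but its gap to compound 1 lies within the scatter. Compound 3 `COC(=O)[C@@]1(C)CC[C@@H]2C3=C1CC[C@@H](C)[C@]3(C)C[C@@H]1c3cc(Br)ccc3N[C@H]21` carries the change (bromo in place of methyl on an aromatic carbon). Going by the values given here, no measured step exchanges bromo for methyl, so the only bearing is indirect: the hydrogen-to-methyl step at this same carbon was within the scatter, giving no sign that a small group here moves the read-out in this assay. The expected step is a 1.0-fold lower number from compound 2 to compound 3 (0.02 log units; within the scatter), nothing beyond the scatter. Compound 3 is therefore estimated at 22000 nM, with a range from 10000 nM to 45000 nM.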

Compound 3, concentration for 50% growth inhibition: 45000 nM
Estimate against measurement, compound 3: 2.0-fold (0.31 log units) below; the measured number falls inside the stated range.
By their numbers in this assay, from the lowest: compounds 2, 1 and 3 (each within the scatter of the next).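

In this assay bromo in place of methyl gives a 2.0-fold higher number from compound 2 to compound 3 (0.29 log units; within the scatter) and bromo in place of hydrogen gives a 1.5-fold higher number from compound 1 to compound 3 (0.18 log units; within the scatter) so neither exchange at this carbon moves the number beyond the scatter. Hydrogen, methyl and bromo have now all been read at this one aromatic carbon, and all three compounds lie within the scatter of one another, so none of these three groups sets itself apart here. Nothing available on these compounds bears on this result.

Still open, going by these compounds, is whether an amine, a carboxylic acid or a longer chain at this same carbon would carry the number beyond the scatter. Also open, on these data alone, is whether a change elsewhere on the shared core, such as a carboxylic acid in place of the methyl ester, would do so.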